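The source may hold more compounds than are shown below. What is called first, only, known or untested is meant among the compounds shown, and "the series" means these compounds.

Compound 1 `C/C=C/COC(=O)/C=C(C)/C=C/CC(C)CCCC(C)(C)OC` stands lowest of the two numbers in a physicochemical assay for lipophilicity (a higher number here means a more lipophilic compound, a lower number a more polar compound), where compound 1 gives 6.07; its nearest neighbour, compound 2 `CCOC(=O)/C=C(C)/C=C/CC(C)CCC(SCC)C(C)C`, gives 6.9 in this assay, a gap beyond the usual scatter. Compound 3 `C=CCSC(=O)/C=C(C)/C=C/CC(C)CCCC(C)(C)OC` differs from compound 1 in one place: allylsulfanyl in place of (but-2-en-1-yl)oxy on a carbonyl carbon. Among the measured compounds shown here, no measured pair shows this change, so the step can only be expected, and a modest rise of about a number 0.33 log units higher from compound 1 to compound 3 (beyond the scatter) is expected, one that may well remain within the scatter. Compound 3 is accordingly estimated at 6.4 in this assay, with a range from 5.8 to 7.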

Compound 3, partition coefficient: 6.77
The estimate for compound 3 lay 0.37 log units below the measured number; measured number inside the range.
By their numbers in this assay, from the lowest: compound 1; then compounds 3 and 2 (each within the scatter of the next).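

Allylsulfanyl in place of (but-2-en-1-yl)oxy on a carbonyl carbon gives, in this assay, a number 0.70 log units higher from compound 1 to compound 3 (beyond the scatter). Among the compounds shown here, this is the first step read at this position, and it shows that the group on the carbonyl carbon can move this number beyond the scatter. Nothing available explains the size of this step.

The change swaps the linking atom and the chain together, so the step cannot separate the two. Allyloxy on the same carbonyl carbon would tell them apart, and how an amine there would read remains open.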